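Swapping the hydroxyalkyl chain for a cyclic ether

The source may hold more compounds than are shown below. What is called first, only, known or untested is meant among the compounds shown, and "the series" means these compounds.

Measured so far:
compound 1 `Cc1c(Nc2nc(N)c3c(C#N)c(N4CCC[C@H]4C)n(C)c3n2)cnn1C1COC1`: 300 nM
compound 2 `Cc1c(Nc2nc(N)c3c(C#N)c(N4CCC[C@H]4C)n(C)c3n2)cnn1CC(C)(C)O`: 280 nM

All numbers come from an assay on HEK293 cells for inhibition of Leucine-rich repeat serine/threonine-protein kinase 2 (Homo sapiens), with a stated time of 48 h; a lower number here means a stronger inhibitor, a higher number a weaker inhibitor. Compound 2 gives 280 nM, and compound 1 gives 300 nM; the two values lie within the scatter of each other, as the step of a 1.1-fold lower number from compound 1 to compound 2 (0.03 log units; within the scatter) shows. Compound 3 `Cc1c(Nc2nc(N)c3c(C#N)c(N4CCC[C@H]4C)n(C)c3n2)cnn1[C@@H]1CCOC1` carries oxolan-3-yl in place of 2-hydroxy-2-methylpropyl on an aromatic nitrogen. For the measured compounds named here, the only measured step, a 1.1-fold lower number from compound 1 to compound 2 (0.03 log units; within the scatter), replaced oxetan-3-yl with 2-hydroxy-2-methylpropyl without moving the number. For compound 3, which brings in oxolan-3-yl instead, a similarly small shift is therefore expected, giving a 1.0-fold lower number from compound 2 to compound 3 (0.02 log units; within the scatter). Compound 3 is thus estimated at 270 nM, with a range from 130 nM to 560 nM.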

Compound 3, half-maximal inhibitory concentration: 180 nM
Compound 3: the middle estimate sits 1.5-fold (0.18 log units) above what was measured; low and high end bracket the measured number.
By their numbers in this assay, from the lowest: compounds 3, 2 and 1 (each within the scatter of the next).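

In this assay, the step of a 1.6-fold lower number from compound 2 to compound 3 (0.19 log units; within the scatter) and the step of a 1.7-fold lower number from compound 1 to compound 3 (0.22 log units; within the scatter) both stay within the scatter, so all three groups on this aromatic nitrogen read alike. Oxolan-3-yl has the same heavy-atom count as 2-hydroxy-2-methylpropyl but no hydrogen-bond donor, and the number still stays within the scatter. No supporting measurement bears on this result.

From the compounds shown here alone, it remains open whether an amine or a carboxylic acid on this nitrogen would stay in this range. The oxolan-3-yl with the opposite stereocentre also remains an open comparison with compound 3.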